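Nitro for hydrogen on the benzyl ether of compound 2

This account rests on a few compounds, and the source may have more. Where it says the series, first, only, none or still open, it means among the compounds named here.

Two compounds of the series share one core and differ only on the benzyloxy ring. Compound 1 `FC(F)(F)c1ccc(COc2cccc(Nc3ncnc4cc5c(cc34)OCCOCCOCCO5)c2)cc1` carries a trifluoromethyl there; compound 2 `c1ccc(COc2cccc(Nc3ncnc4cc5c(cc34)OCCOCCOCCO5)c2)cc1` carries hydrogen. In a functional assay on A549 cells (Homo sapiens) for antiproliferative activity, read by MTT assay, with a stated time of 72 h (on this read-out higher numbers stand for weaker inhibition and lower numbers for stronger inhibition), compound 1 gives 24900 nM. For compound 2 this assay reports only a limit, > 100000 nM. Compound 2 therefore stands at the weaker end of the two numbers shown, as far as a limit allows, and the only measured step, an at least 4.0-fold higher number from compound 1 to compound 2 (0.60 log units; beyond the scatter), rests on (the limit of > 100000 nM in this assay, at which 1 of the 2 values shown sits).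

Compound 3 `O=[N+]([O-])c1ccc(COc2cccc(Nc3ncnc4cc5c(cc34)OCCOCCOCCO5)c2)cc1` differs from compound 2 in one place: nitro in place of hydrogen on an aromatic carbon. For the measured compounds named here, the one step measured at this position, a substituent entering in place of hydrogen, lowered the number, so the expectation for a nitro entering at the same place is a lower number, of roughly the same size as that step, though the limit leaves its true size open. Compound 3 is therefore expected to give about 30000 nM, between 10000 nM and 100000 nM. The expected step is an at least 3.3-fold lower number from compound 2 to compound 3 (0.52 log units; beyond the scatter).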

Compound 3, half-maximal inhibitory concentration: > 100000 nM
Compound 3 gave a limit, no number (the forecaster's own chance of this, stated with the estimate: 30%); middle value at least 3.3-fold (0.52 log units) from the limit.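

Nitro in place of trifluoromethyl on the benzyl ether gives an at least 4.0-fold higher number from compound 1 to compound 3 (0.60 log units; beyond the scatter), so the two substituents at this place are not interchangeable in this assay. A substituent entering in place of hydrogen therefore does not by itself bring a measurable number: among the compounds shown, compound 1 fits that reading and compound 3 goes against it, since its value is only a limit. The step between compound 2 and compound 3 cannot be read, because both values are limits, so nitro and hydrogen cannot be told apart here: the limit of > 100000 nM in this assay, at which 2 of the 3 values shown sit.

Going by these compounds, how far compound 2 and compound 3 lie past the limit stays open, and with it any order between hydrogen and nitro at this place. On these data alone, whether the measurable number of compound 1 belongs to trifluoromethyl alone or is shared by other groups at the same place, such as a chlorine atom, a methoxy, an amine or a carboxylic acid, also stays open.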